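Swapping the ring on the sulfonyl sulfur: a step toward compound 4

The compounds below may be only part of what the source reports. "The series", "measured", "known", "first", "only" and "open" are said of these compounds alone.

Three compounds have so far been measured in an ADME assay on HEK293 cells (Homo sapiens) for cytotoxicity, read by resazurin assay, with a stated time of 48 h; on this read-out lower numbers stand for higher toxicity in this test and higher numbers for lower toxicity in this test:
- compound 1, `O=S(=O)(Nc1ccc2oc(-c3ccccc3)nc2c1)c1cccc(Cl)c1`, gives 70000 nM.
- compound 3, `O=S(=O)(Nc1ccc2oc(-c3ccccc3)nc2c1)c1ccccc1O`, gives 33000 nM.
- compound 2, `O=S(=O)(Nc1ccc(-c2nc3ccccc3o2)cc1)c1cccs1`, reaches only the limit of the test, > 100000 nM.

Compound 2 thus stands at the edge of what this test can report: its value is a limit, not a number, and it sits at the limit of > 100000 nM in this assay, at which 1 of the 3 values shown sits. Compound 4, `COc1cccc(S(=O)(=O)Nc2ccc(-c3nc4ccccc4o3)cc2)c1`, has not yet been measured. It differs from compound 2 in one place only: 3-methoxyphenyl in place of thiophen-2-yl on a sulfonyl sulfur. Going by the values given here, the one measured step of a similar kind also exchanges the group on a sulfonyl sulfur, though between compounds whose shared core is arranged differently from that of compound 2: a 2.1-fold lower number from compound 1 to compound 3 (0.33 log units; beyond the scatter). Both compound 1 and compound 3 lie inside the measurable range, whereas compound 2 starts from a limit, so the comparison is loose. Since that exchange gave only a modest shift, a step of about that size, in either direction, is expected for compound 4, a number no higher from compound 2 to compound 4 (the limit leaves the size open). Compound 4 is therefore estimated at 100000 nM, with a range from 40000 nM to 250000 nM, and a fair chance that this assay again reports only a limit.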

Compound 4, half-maximal cytotoxic concentration: > 100000 nM
Compound 4: only a limit was reported (the forecaster's own chance of this, stated with the estimate: 50%); the middle value sits exactly at the limit.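

Compound 2 and compound 4 each give only a limit in this assay, not a number, so the step between them cannot be read: the limit of > 100000 nM in this assay, at which 2 of the 4 values shown sit. As far as these compounds go, what stays open is how far either compound lies from that limit, and whether 3-methoxyphenyl in place of thiophen-2-yl on the sulfonyl sulfur changes the read-out at all.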